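This account rests on a few compounds, and the source may have more. Where it says the series, first, only, none or still open, it means among the compounds named here.

Compound 1 `Brc1ccc(C2CC(c3ccccc3)=NN2c2ccccc2)cc1` gives 3160 nM in an assay for inhibition of cathepsin H (Capra hircus), using Lineweaver-Burk analysis (on this read-out lower numbers stand for stronger inhibition and higher numbers for weaker inhibition), which is the second highest of the three numbers reported. Compound 2 `Cc1ccc(C2CC(c3ccccc3)=NN2c2ccccc2)cc1` gives 4180 nM in this assay, and compound 3 `COc1ccc(C2CC(c3ccccc3)=NN2c2ccccc2)cc1` gives 2120 nM. The steps between them, a 1.3-fold higher number from compound 1 to compound 2 (0.12 log units; within the scatter), a 1.5-fold lower number from compound 1 to compound 3 (0.17 log units; within the scatter) and a 2.0-fold lower number from compound 2 to compound 3 (0.29 log units; within the scatter), all concern a change on an aromatic carbon and all lie within the scatter. Compound 4 `Brc1ccc(C2CC(c3ccccc3)=NN2)cc1` differs from compound 1 by hydrogen in place of phenyl on an amine nitrogen in a ring. For the measured compounds named here, none of the measured steps touches this part of the core, so they offer no direct guide, and the expected change is none beyond the scatter, with wide uncertainty. The step from compound 1 to compound 4 is expected to be a 1.3-fold higher number from compound 1 to compound 4 (0.10 log units; within the scatter). Compound 4 is accordingly estimated at 4000 nM, likely between 1000 nM and 16000 nM.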

Compound 4, inhibition constant: 5380 nM
Compound 4: middle estimate off by 1.3-fold (0.13 log units), on the low side, within the range that was stated.
By their numbers in this assay, from the lowest: compounds 3, 1, 2 and 4 (each within the scatter of the next, the first and the last beyond it).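

In this assay, replacing the phenyl on the amine nitrogen in the ring with hydrogen gives a 1.7-fold higher number from compound 1 to compound 4 (0.23 log units; within the scatter) and so stays within the scatter. The earlier steps shown here, all on an aromatic carbon, could not show that this nitrogen tolerates the loss of a whole phenyl group without a change beyond the scatter. Nothing measured here offers a reason for this.

The compounds shown leave open whether an acetyl group or a longer alkyl chain on this nitrogen would move the number beyond the scatter.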